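The source may hold more compounds than are shown below. What is called first, only, known or untested is meant among the compounds shown, and "the series" means these compounds.

Measured compounds:
compound 1 `Cc1cccc(Nc2nccc(-c3ccc(C)o3)n2)c1`: 2000 nM
compound 2 `Cc1cccc(Nc2nccc(-c3ccc(C)s3)n2)c1`: 1400 nM

In a functional assay for inhibition, with Homo sapiens as the target (a lower number here means a stronger inhibitor, a higher number a weaker inhibitor), compound 1 gives 2000 nM and compound 2 gives 1400 nM. The only measured step, a 1.4-fold lower number from compound 1 to compound 2 (0.15 log units; within the scatter), lies within the scatter, so these two compounds cannot be told apart on the numbers shown, and compound 2 holds the lower of two numbers only in appearance.

Compound 3 `Cc1cccc(Nc2nccc(-c3ccco3)n2)c1` is the next compound to be measured. Its change from compound 2 is furan-2-yl in place of 5-methylthiophen-2-yl on an aromatic carbon. The step from compound 1 to compound 2 bears on it in part: it shows that trading the oxygen-containing ring for the sulfur-containing ring, with the methyl kept, changed little. For the measured compounds named here, no measured step shows what removing the methyl does, so that part stays open. In this assay a step of a 1.8-fold higher number from compound 2 to compound 3 (0.25 log units; within the scatter) is therefore expected, small and possibly toward a weaker inhibitor. Compound 3 is estimated at 2500 nM, within 1000 nM to 6500 nM.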

Compound 3, half-maximal inhibitory concentration: 2100 nM
For compound 3 the middle estimate is 1.2-fold (0.08 log units) above the measured one; the measured number falls inside the stated range.
By their numbers in this assay, from the lowest: compounds 2, 1 and 3 (each within the scatter of the next).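

In this assay, for the compounds shown here, hydrogen in place of methyl on the furan ring gives a 1.1-fold higher number from compound 1 to compound 3 (0.02 log units; within the scatter), which is the first direct reading of what the methyl does; on these numbers, its removal has no effect that can be told from the scatter. The larger swap, furan-2-yl in place of 5-methylthiophen-2-yl, gives a 1.5-fold higher number from compound 2 to compound 3 (0.18 log units; within the scatter), also within the scatter, so all three groups tested on this aromatic carbon remain indistinguishable in this assay. No supporting evidence bears on this result.

The compounds shown leave open what thiophen-2-yl, the sulfur-containing ring without its methyl, would give. They also leave open whether a very different group at this position, such as an amine or a carboxylic acid, would shift the number beyond the scatter.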